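Sulfone series: trihydroxyphenyl in place of methoxyphenyl

The source may hold more compounds than are shown below. What is called first, only, known or untested is meant among the compounds shown, and "the series" means these compounds.

Working notes on a small set of aryl vinyl sulfur compounds tested in a functional assay on DU-145 cells (Homo sapiens) for inhibition, read by trypan blue exclusion, with a stated time of 96 h; on this read-out higher numbers stand for weaker inhibition of growth and lower numbers for stronger inhibition of growth. Of the compounds shown here, two have numbers so far. Compound 1, `Cc1ccc(S/C(=C/c2c(O)cc(O)cc2O)C(=O)c2ccc(Br)cc2)cc1`, returns only a limit in this assay, at > 100000 nM. Compound 2, `COc1ccc(/C=C(\C(=O)c2ccc(Br)cc2)S(=O)(=O)c2ccc(C)cc2)cc1`, is the one compound with a measured number: in this assay compound 2 gives 1000 nM, and it therefore stands alone among the figures shown. The other entry, that of compound 1, is a limit rather than a number (the limit of > 100000 nM in this assay, at which 1 of the 2 values shown sits).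

The next compound, compound 3, `Cc1ccc(S(=O)(=O)/C(=C/c2c(O)cc(O)cc2O)C(=O)c2ccc(Br)cc2)cc1`, is built from compound 2 by a single change: 2,4,6-trihydroxyphenyl in place of 4-methoxyphenyl on a double-bonded chain carbon bound to a double-bonded chain carbon.

Among the measured compounds shown here, no step between two measured compounds is available to calibrate this change. For the measured compounds named here, the only other value in the set is the limit of compound 1. On that basis compound 3 is expected to show weaker growth inhibition than compound 2, with the step from compound 2 to compound 3 estimated as a 15-fold higher number from compound 2 to compound 3 (1.18 log units; beyond the scatter), a move beyond the usual scatter. Compound 3 is expected to come in at 15000 nM, within a range from 2000 nM to 100000 nM, with a real chance that the read-out again returns only a limit.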

Compound 3, concentration for 50% growth inhibition: > 100000 nM
Compound 3 ended at the assay's limit; the forecaster's own chance of this, stated with the estimate: 30%; middle value at least 6.6-fold (0.82 log units) from the limit.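

On the double-bonded chain carbon bound to a double-bonded chain carbon, 2,4,6-trihydroxyphenyl in place of 4-methoxyphenyl weakens growth inhibition in this assay, with an at least 100-fold higher number from compound 2 to compound 3 (2.00 log units; beyond the scatter), and the size of this step rests on a limit. This gives the series its first readable step and shows that this position is not indifferent to the aromatic group it carries. With 2,4,6-trihydroxyphenyl in place, the step between the (4-methylphenyl)sulfanyl and (4-methylphenyl)sulfonyl compounds cannot be read, and most of the set now rests on a limit: the limit of > 100000 nM in this assay, at which 2 of the 3 values shown sit.

From the compounds shown here alone, the true size of the loss remains open, as does whether it follows from the arrival of the hydroxyl groups, from the departure of the methoxy group, or from the number of groups on the ring; a plain phenyl or a trimethoxyphenyl at this place would help to separate these readings. Going by these compounds, the effect of sulfanyl against sulfonyl also remains open, and a compound pairing (4-methylphenyl)sulfanyl with 4-methoxyphenyl would bear on it directly.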